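The source may report more compounds than this note shows. Statements on the series, on what has been measured and on what is new or still open speak of the compounds shown alone.

Compound 1 `COc1ccc(-c2csc(N3N=C(c4ccc(F)cc4)CC3c3ccc4c(c3)OCCO4)n2)cc1`: in a functional assay on MCF7 cells (Homo sapiens) for antiproliferative activity, read by MTT assay, with a stated time of 48 h (a higher number here means a weaker inhibitor, a lower number a stronger inhibitor), compound 1 gives 4530 nM. Compound 2 `COc1ccc(C2=NN(c3nc(-c4ccc(OC)cc4)cs3)C(c3ccc4c(c3)OCCO4)C2)cc1`: compound 2 gives 2730 nM. Compound 3 `Fc1ccc(C2=NN(c3nc(-c4ccc(Br)cc4)cs3)C(c3ccc4c(c3)OCCO4)C2)cc1`: compound 3 gives 4200 nM.

Compound 3 stands second highest of the three numbers in this assay; its gaps to compound 1 and to compound 2 both lie within the scatter. Compound 4 `COc1ccc(C2=NN(c3nc(-c4ccc(Br)cc4)cs3)C(c3ccc4c(c3)OCCO4)C2)cc1` differs from compound 3 in one place: methoxy in place of fluoro on an aromatic carbon. The same change has been seen once among the measured compounds, a 1.7-fold lower number from compound 1 to compound 2 (0.22 log units; within the scatter). That step stayed within the scatter, so for compound 4 no step beyond the scatter is expected in this assay, with at most a somewhat lower number. Compound 4 is therefore estimated at 3000 nM, between 1500 nM and 6000 nM, which corresponds to an expected step of a 1.4-fold lower number from compound 3 to compound 4 (0.15 log units; within the scatter).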

Compound 4, half-maximal inhibitory concentration: 2540 nM
For compound 4 the middle estimate is 1.2-fold (0.07 log units) above the measured one; measured number inside the range.
By their numbers in this assay, from the lowest: compounds 4, 2, 3 and 1 (each within the scatter of the next).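

On a second core the change from 4-fluorophenyl to 4-methoxyphenyl again stays within the scatter in this assay, with a 1.7-fold lower number from compound 3 to compound 4 (0.22 log units; within the scatter), and its size repeats: the same change on two cores in this assay, a 1.7-fold lower number (0.22 log units; within the scatter) from compound 1 to compound 2 and a 1.7-fold lower number (0.22 log units; within the scatter) from compound 3 to compound 4, 1.0-fold (0.00 log units) apart, within the scatter of two such steps. Bromo in place of methoxy likewise gives a 1.1-fold lower number from compound 2 to compound 4 (0.03 log units; within the scatter), and that step repeats too: the same change on two cores in this assay, a 1.1-fold lower number (0.03 log units; within the scatter) from compound 1 to compound 3 and a 1.1-fold lower number (0.03 log units; within the scatter) from compound 2 to compound 4, 1.0-fold (0.00 log units) apart, within the scatter of two such steps. Across these four compounds, neither change moves the number beyond the scatter, and each reads the same on both cores. The compounds shown leave open whether any group on this ring can produce a step beyond the scatter, for instance an amine or a carboxylic acid in place of the methoxy.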